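Para substituent on the aryl ketone: iodo to methyl

A few compounds are considered here, and "the series" means these few. Any claim that something is new, unique, unknown or untested is made for them only; others in the source may bear on it.

In a functional assay on SK-OV-3 cells (Homo sapiens) for cytotoxicity, read by MTT assay, with a stated time of 48 h (on this read-out lower numbers stand for stronger inhibition and higher numbers for weaker inhibition), compound 2 `O=C(/C=C/c1ccc2c(c1)B(O)OC2)c1ccc(I)cc1` gives 4200 nM, and compound 1 `O=C(/C=C/c1ccc2c(c1)B(O)OC2)c1ccc(Br)cc1` gives 4500 nM. The step of a 1.1-fold lower number from compound 1 to compound 2 (0.03 log units; within the scatter) does not separate the two, so compound 2 stands beside compound 1 on these numbers rather than apart from it. Compound 3 `Cc1ccc(C(=O)/C=C/c2ccc3c(c2)B(O)OC3)cc1` differs from compound 2 by methyl in place of iodo on an aromatic carbon. For the measured compounds named here, the only measured step at this place is a 1.1-fold lower number from compound 1 to compound 2 (0.03 log units; within the scatter), a swap of one halogen for another, and it stayed within the scatter. Going by the values given here, no measured step shows a halogen leaving for methyl, so the size of this change is not read directly from the series. With one halogen swap flat, the step is expected to be small, with the direction uncertain. The expected step of a 1.2-fold higher number from compound 2 to compound 3 (0.08 log units; within the scatter) is therefore taken as within or only just beyond the scatter. Compound 3 is expected near 5000 nM, between 2000 nM and 12000 nM.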

Compound 3, half-maximal inhibitory concentration: 3700 nM
Estimate against measurement, compound 3: 1.4-fold (0.13 log units) above; measured number inside the range.
By their numbers in this assay, from the lowest: compounds 3, 2 and 1 (each within the scatter of the next).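

In this assay methyl in place of iodo gives a 1.1-fold lower number from compound 2 to compound 3 (0.06 log units; within the scatter) and methyl in place of bromo gives a 1.2-fold lower number from compound 1 to compound 3 (0.09 log units; within the scatter) on the same aromatic carbon. The earlier compounds shown here covered only a swap of one halogen for another, whereas these steps show that a group other than a halogen at this position also leaves the number within the scatter, so compounds 1, 2 and 3 are not separated on this read-out. No supporting measurement is at hand to explain why the three read alike.

From the compounds shown here alone, whether an amine, a carboxylic acid or a longer chain at this position would separate from these three stays open. Going by these compounds, with the rest of the structure shared across compounds 1, 2 and 3, whether this flat reading holds alongside a change elsewhere on the core also stays open.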